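Mirror image of compound 1: what to expect

This account rests on a few compounds, and the source may have more. Where it says the series, first, only, none or still open, it means among the compounds named here.

Measured compounds:
compound 1 `OC[C@@H]1O[C@@H](n2c(SCc3ccccc3)nc3cc(Cl)c(Cl)cc32)[C@H](O)[C@@H]1O` – 40000 nM
compound 2 `OC[C@H]1O[C@H](n2c(Br)nc3cc(Cl)c(Cl)cc32)[C@@H](O)[C@H]1O` – > 100000 nM; > 100000 nM (2 entries), a limit (two entries)

Going by the values given here, compound 1 `OC[C@@H]1O[C@@H](n2c(SCc3ccccc3)nc3cc(Cl)c(Cl)cc32)[C@H](O)[C@@H]1O` is the only compound that yields an actual number in a functional assay on KB cells (Homo sapiens) for inhibition; on this read-out lower numbers stand for stronger inhibition and higher numbers for weaker inhibition: there compound 1 gives 40000 nM, a weak result. Compound 2 `OC[C@H]1O[C@H](n2c(Br)nc3cc(Cl)c(Cl)cc32)[C@@H](O)[C@H]1O` reaches only a limit of the assay in this assay, namely > 100000 nM; > 100000 nM (2 entries) in both of its entries, so it contributes no number to compare against.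

Compound 3 `OC[C@H]1O[C@H](n2c(SCc3ccccc3)nc3cc(Cl)c(Cl)cc32)[C@@H](O)[C@H]1O` has the same atoms and bonds as compound 1 and differs from it only as follows: the two compounds have the same atoms and bonds and differ only in configuration as drawn: 4 of 4 stereo elements differ (all stereocentres are inverted: mirror images); a stereocentre at a saturated ring carbon is drawn S in compound 1 and R in compound 3; a stereocentre at a saturated ring carbon is drawn R in compound 1 and S in compound 3; a stereocentre at a saturated ring carbon is drawn R in compound 1 and S in compound 3; a stereocentre at a saturated ring carbon is drawn S in compound 1 and R in compound 3. Among the compounds with values here, no step between two measured compounds is available, so nothing in the data says how large the move from one mirror image to the other will be in this assay. Since compound 1 is already weak at 40000 nM, the expectation is a step of modest size toward weaker inhibition; the expected step is a 1.8-fold higher number from compound 1 to compound 3 (0.24 log units; within the scatter). For compound 3 the estimate in this assay is 70000 nM, within a range from 20000 nM to 200000 nM.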

Compound 3, half-maximal inhibitory concentration: 60000 nM
Compound 3: the middle estimate sits 1.2-fold (0.07 log units) above what was measured, and the stated range covers the measured number.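

Going by these compounds alone, with the first step between two measured compounds, this assay reads a 1.5-fold higher number from compound 1 to compound 3 (0.18 log units; within the scatter), so inverting all four stereocentres leaves the two mirror images indistinguishable on this read-out. As far as these compounds go, the comparison isolates configuration, as nothing else separates the pair: the fact that compounds 1 and 3 differ only in the configuration as drawn Compound 3 also shares its drawn configuration with compound 2, and compound 3 returns an actual number where compound 2, which carries bromine in place of the benzylthio group, gives only a limit of the assay in both entries; that pair has no readable step, so the size of any difference between them remains unknown.

The compounds shown leave open whether the mirror images would stay this close with an amine or a longer alkylthio chain in place of the benzylthio group, and whether this closeness would hold at a stronger level of inhibition than the weak one seen here. Within the data shown here, they also leave open what inverting only one of the four stereocentres would do, since the single step available inverts all of them together.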